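Swapping the phenyl of compound 1 for a substituted pyrrolyl

The source may report more compounds than this note shows. Statements on the series, on what has been measured and on what is new or still open speak of the compounds shown alone.

Compound 1 `O=C(N/N=C/c1ccccc1)Nc1ccc(Oc2ccnc3[nH]ccc23)c(F)c1` was tested in a functional assay on A549 cells (Homo sapiens) for antiproliferative activity, read by MTT assay, with a stated time of 72 h (a higher number here means a weaker inhibitor, a lower number a stronger inhibitor), and gave 2500 nM. Two relatives differ from it in one place. Compound 2 `O=C(N/N=C/c1cccc([N+](=O)[O-])c1)Nc1ccc(Oc2ccnc3[nH]ccc23)c(F)c1` gives 3640 nM in this assay, and compound 3 `O=C(N/N=C/c1ccc(O)cc1)Nc1ccc(Oc2ccnc3[nH]ccc23)c(F)c1` gives 3760 nM. The steps of a 1.5-fold higher number from compound 1 to compound 2 (0.16 log units; within the scatter) and a 1.5-fold higher number from compound 1 to compound 3 (0.18 log units; within the scatter) are each within the scatter, and so is a 1.0-fold higher number from compound 2 to compound 3 (0.01 log units; within the scatter). Compound 1 shows the lowest number of the three, though its gaps to compound 2 and compound 3 are within the scatter, so no ranking among them can be claimed.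

Compound 4 `CN(C)CCn1cccc1/C=N/NC(=O)Nc1ccc(Oc2ccnc3[nH]ccc23)c(F)c1` has not yet been measured in this assay. It differs from compound 1 as follows: 1-(2-(dimethylamino)ethyl)-1H-pyrrol-2-yl in place of phenyl on a carbon with a double bond to nitrogen. For the measured compounds named here, the measured steps all keep the phenyl ring in place and only add a group to it; none swaps that ring for another, so no step bears directly on this change. Those steps, a 1.5-fold higher number from compound 1 to compound 2 (0.16 log units; within the scatter) and a 1.5-fold higher number from compound 1 to compound 3 (0.18 log units; within the scatter), were small, but a replacement of the whole ring is a larger change than either. No step beyond the scatter is therefore expected in this assay, with a wide range allowed. Compound 4 is estimated at 2200 nM, between 700 nM and 7000 nM, which would mean an expected step of a 1.1-fold lower number from compound 1 to compound 4 (0.06 log units; within the scatter).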

Compound 4, half-maximal inhibitory concentration: "not active" (no number reported)
Compound 4 has no reported number here; there is nothing to compare the estimate with.
By their numbers in this assay, from the lowest: compounds 1, 2 and 3 (each within the scatter of the next).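

In this assay, for the compounds shown here, compound 4 is reported as not active with no number, so no step linking it to compound 1, compound 2 or compound 3 can be read. As far as these compounds go, it remains open how far compound 4 lies from these three, and whether the pyrrolyl ring or its 2-(dimethylamino)ethyl chain matters more. No measurement shown here offers an explanation for this result.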